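Enaminone Series: Trimethoxyphenyl Replacing Hydroxyphenyl on the Amine

The source may hold more compounds than are shown below. What is called first, only, known or untested is meant among the compounds shown, and "the series" means these compounds.

Measured so far:
compound 1, `COc1ccc(-c2nn(-c3ccccc3)cc2C(=O)/C=C\Nc2cc(OC)c(OC)c(OC)c2)cc1`, > 50000 nM
compound 2, `COc1cc(-c2nn(-c3ccccc3)cc2C(=O)/C=C\Nc2ccc(O)cc2)cc(OC)c1OC`, 17600 nM

In an ADME assay on HaCaT cells (Homo sapiens) for antiproliferative activity, read by MTT assay, with a stated time of 48 h (on this read-out higher numbers stand for weaker inhibition and lower numbers for stronger inhibition), compound 2 gives 17600 nM. Going by the values given here, compound 2 is the only compound here with a number rather than a limit. Compound 1 reaches only (the limit of > 50000 nM in this assay, at which 1 of the 2 values shown sits), which is a limit of the assay and not a number.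

Compound 3, `COc1cc(N/C=C\C(=O)c2cn(-c3ccccc3)nc2-c2cc(OC)c(OC)c(OC)c2)cc(OC)c1OC`, carries 3,4,5-trimethoxyphenyl in place of 4-hydroxyphenyl on an amine nitrogen, that is, 3,4,5-trimethoxyphenyl in place of 4-hydroxyphenyl on an amine nitrogen. Among the compounds with values here, no step between measured compounds with this change is available, so nothing shows its size or direction here. Compound 1, which also carries 3,4,5-trimethoxyphenyl on the amine nitrogen, sits at a limit, while compound 2 carries 4-hydroxyphenyl there and gives a number; beyond that the two compounds differ in a second place, so the comparison is not clean.

The expected step from compound 2 to compound 3 is a 2.0-fold higher number from compound 2 to compound 3 (0.30 log units; within the scatter), towards weaker inhibition. Compound 3 is estimated at 35000 nM, with a range from 9000 nM to 120000 nM.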

Compound 3, half-maximal inhibitory concentration: 20900 nM
Compound 3: the middle estimate sits 1.7-fold (0.22 log units) above what was measured; measured number inside the range.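

In this assay, going by these compounds alone, the first clean step at the amine nitrogen, 3,4,5-trimethoxyphenyl in place of 4-hydroxyphenyl, gives a 1.2-fold higher number from compound 2 to compound 3 (0.07 log units; within the scatter), so the read-out does not separate these two groups at this position. On the aromatic carbon, 3,4,5-trimethoxyphenyl in place of 4-methoxyphenyl gives an at least 2.3-fold lower number from compound 1 to compound 3 (0.37 log units; beyond the scatter), so among the compounds shown, only this change moves the read-out beyond the scatter. The value of compound 1 is a limit of the assay and not a number, so the full size of that step stays unknown: the limit of > 50000 nM in this assay, at which 1 of the 3 values shown sits.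

Still open, on these data alone, is how 4-methoxyphenyl on the aromatic carbon reads when paired with 4-hydroxyphenyl on the amine nitrogen. Also open, as far as these compounds go, is whether a 4-aminophenyl or 4-carboxyphenyl group on that nitrogen would read any differently.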